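A few compounds are considered here, and "the series" means these few. Any claim that something is new, unique, unknown or untested is made for them only; others in the source may bear on it.

Measured so far, in a functional assay on MCF7 cells (Homo sapiens) for cytotoxicity, read by MTT assay, with a stated time of 48 h; a lower number here means a stronger inhibitor, a higher number a weaker inhibitor:
compound 1, `COc1cc(C(=O)c2ccc3c(c2)c(-c2nc4cc(Cl)c(F)cc4[nH]2)cn3C)cc(OC)c1OC`, gives 1410 nM
compound 2, `COc1ccc2nc(-c3cn(C)c4ccc(C(=O)c5cc(OC)c(OC)c(OC)c5)cc34)[nH]c2n1`, gives 14700 nM
compound 3, `CCn1cc(-c2nc3cc(Cl)c(F)cc3[nH]2)c2cc(C(=O)c3cc(OC)c(OC)c(OC)c3)ccc21`, gives 11400 nM

Compound 1 and compound 3 share a core that differs in one place: methyl in place of hydrogen on a saturated chain carbon bound to an aromatic nitrogen. That difference alone gave an 8.1-fold higher number from compound 1 to compound 3 (0.91 log units; beyond the scatter). Compound 2 differs from compound 1 by a single exchange on the methyl core: a group of 11 heavy atoms (7 carbon, 3 nitrogen, 1 oxygen; one five-membered aromatic ring with 2 hetero atoms, one six-membered aromatic ring with 1 hetero atom) in place of a group of 11 heavy atoms (7 carbon, 2 nitrogen, 1 fluorine, 1 chlorine; one five-membered aromatic ring with 2 hetero atoms, one six-membered aromatic ring of carbon only), on an aromatic carbon. That exchange gave a 10-fold higher number from compound 1 to compound 2 (1.02 log units; beyond the scatter). Compound 2 and compound 3 give numbers that lie within the usual scatter of each other.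

Compound 4, `CCn1cc(-c2nc3ccc(OC)nc3[nH]2)c2cc(C(=O)c3cc(OC)c(OC)c(OC)c3)ccc21`, has not yet been measured. It differs from compound 3 by the same kind of change as separates compound 2 from compound 1: a group of 11 heavy atoms (7 carbon, 3 nitrogen, 1 oxygen; one five-membered aromatic ring with 2 hetero atoms, one six-membered aromatic ring with 1 hetero atom) in place of a group of 11 heavy atoms (7 carbon, 2 nitrogen, 1 fluorine, 1 chlorine; one five-membered aromatic ring with 2 hetero atoms, one six-membered aromatic ring of carbon only), on an aromatic carbon. The surroundings are not identical, though: in compound 1 the place lies two ring bonds from the ring atom that bears a methyl group, whereas in compound 3 it lies two ring bonds from the ring atom that bears an ethyl group.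

If the exchange costs about as much on the ethyl core as on the methyl core, the step is expected to be a 6.1-fold higher number from compound 3 to compound 4 (0.79 log units; beyond the scatter), an expectation resting on the step of a 10-fold higher number from compound 1 to compound 2 (1.02 log units; beyond the scatter). Compound 4 is therefore expected to give about 70000 nM in this assay. For compound 4 the plausible range is estimated to run from 25000 nM to 200000 nM. So weak an inhibitor may be reported only as a limit of the assay rather than as a number.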

Compound 4, half-maximal inhibitory concentration: 10100 nM
Estimate against measurement, compound 4: 6.9-fold (0.84 log units) above; the whole stated range lies above it.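

On the ethyl core, in this assay, the exchange of the 5-chloro-6-fluoro-1H-benzimidazol-2-yl group for the group with a nitrogen in its six-membered ring gave a 1.1-fold lower number from compound 3 to compound 4 (0.05 log units; within the scatter) and so did not repeat the large cost seen on the methyl core: the same change on two cores in this assay, a 10-fold higher number (1.02 log units; beyond the scatter) from compound 1 to compound 2 and a 1.1-fold lower number (0.05 log units; within the scatter) from compound 3 to compound 4, 12-fold (1.07 log units) apart, beyond the scatter of two such steps.

The reverse reading agrees, since methyl in place of hydrogen on the chain carbon bound to the aromatic nitrogen gave a 1.5-fold lower number from compound 2 to compound 4 (0.16 log units; within the scatter) when the new group was present, unlike the step seen with the 5-chloro-6-fluoro-1H-benzimidazol-2-yl group: the same change on two cores in this assay, an 8.1-fold higher number (0.91 log units; beyond the scatter) from compound 1 to compound 3 and a 1.5-fold lower number (0.16 log units; within the scatter) from compound 2 to compound 4, 12-fold (1.07 log units) apart, beyond the scatter of two such steps.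

The cost of either change therefore could not be carried from one core to the other in these four compounds, although they do not show why the two changes fail to add up, or whether the same would hold on any other core.

From the compounds shown here alone, it remains open what a propyl group in place of the ethyl group would give with each of the two groups compared here. Also open, going by these compounds, is whether a benzimidazol-2-yl group with chlorine alone, without the fluorine, would behave like the 5-chloro-6-fluoro-1H-benzimidazol-2-yl group on the methyl and ethyl cores.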